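A few compounds are considered here, and "the series" means these few. Any claim that something is new, unique, unknown or untested is made for them only; others in the source may bear on it.

In a functional assay on J774.A1 cells (Mus musculus) for inhibition, read by Griess assay, with stated times of 1 h and 24 h (on this read-out higher numbers stand for weaker inhibition and lower numbers for stronger inhibition), compound 3 `CCCCOc1ccccc1C1CC(=O)c2ccccc2O1` gives 47700 nM, which lies within the scatter of both compound 2 `CC(C)=CCOc1ccccc1C1CC(=O)c2ccccc2O1` at 34300 nM and compound 1 `CC(C)c1ccc(COc2ccccc2C2CC(=O)c3ccccc3O2)cc1` at 28600 nM. Compound 4 `O=C1CC(c2ccccc2OCc2ccccc2)Oc2ccccc21` differs from compound 3 as follows: phenyl in place of propyl on a saturated chain carbon bound to an oxygen on an aromatic ring. Two measured steps at this same place bear on it. Propyl replaces 4-isopropylphenyl in a 1.7-fold higher number from compound 1 to compound 3 (0.22 log units; within the scatter), and propyl replaces 2-methylprop-1-en-1-yl in a 1.4-fold higher number from compound 2 to compound 3 (0.14 log units; within the scatter). The remaining step, a 1.2-fold higher number from compound 1 to compound 2 (0.08 log units; within the scatter), is equally small. No change beyond the scatter is therefore expected in this assay. The expected result is a 1.4-fold lower number from compound 3 to compound 4 (0.13 log units; within the scatter). Compound 4 is estimated at 35000 nM, with an expected range of 18000 nM to 65000 nM.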

Compound 4, half-maximal inhibitory concentration: 23200 nM
Compound 4: the middle estimate sits 1.5-fold (0.18 log units) above what was measured, within the range that was stated.
By their numbers in this assay, from the lowest: compounds 4, 1, 2 and 3 (each within the scatter of the next, the first and the last beyond it).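

In this assay, among the compounds shown here, phenyl in place of propyl gives a 2.1-fold lower number from compound 3 to compound 4 (0.31 log units; beyond the scatter) and is the first step at this place to pass beyond the scatter, though only modestly. Phenyl in place of 2-methylprop-1-en-1-yl gives a 1.5-fold lower number from compound 2 to compound 4 (0.17 log units; within the scatter) and hydrogen in place of isopropyl on an aromatic carbon gives a 1.2-fold lower number from compound 1 to compound 4 (0.09 log units; within the scatter) and both stay within the scatter. Nothing available accounts for these results. The compounds shown leave open whether an amine or a carboxylic acid in place of isopropyl, or a chain longer than butyl, would shift the number in this assay beyond the scatter.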